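Dropping the phenyl ring from a tetrabromobenzotriazole side chain

The source may report more compounds than this note shows. Statements on the series, on what has been measured and on what is new or still open speak of the compounds shown alone.

Of the compounds shown here, three sharing a tetrabrominated core have been tested in a functional assay on MCF7 cells (Homo sapiens) for antiproliferative activity, read by MTT assay, with a stated time of 48 h, tested at 50 uM; on this read-out higher numbers stand for a weaker effect at the one concentration tested and lower numbers for a stronger effect. Compound 1 `OCC(O)Cn1nc2c(Br)c(Br)c(Br)c(Br)c2n1`, which carries a short chain bearing two hydroxyl groups, gives 109%. Compound 2 `OC(CCn1nc2c(Br)c(Br)c(Br)c(Br)c2n1)c1ccc(Br)cc1`, whose chain ends in a hydroxyl-bearing carbon attached to a bromophenyl ring, gives 15%. Compound 3 `OC(CCn1nc2c(Br)c(Br)c(Br)c(Br)c2n1)c1ccccc1` gives 23%, placing it second highest of the three numbers; it sits nearest compound 2 and furthest from compound 1. Going by the values given here, the only measured step, a number 8 percentage points higher from compound 2 to compound 3 (within the scatter), involves a hydrogen in place of bromo on an aromatic carbon and lies within the scatter.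

Compound 4 `CC(O)CCn1nc2c(Br)c(Br)c(Br)c(Br)c2n1` has not yet been measured. It differs from compound 3 in one place: methyl in place of phenyl on a saturated chain carbon bound to an oxygen on a saturated carbon and a saturated chain carbon. Among the compounds with values here, no measured step covers this change directly. The nearest guide is that compound 1, which also lacks any ring on the chain, gives a much higher number than compound 3, while compounds 2 and 3, both carrying a ring there, give low numbers. Because compound 1 gives 109%, compound 4 is expected to give about 85%, between 50% and 112%. This estimated change corresponds to a number 62 percentage points higher from compound 3 to compound 4 (beyond the scatter), a rise beyond the scatter.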

Compound 4, a percentage reported as activity, at one concentration (the size of the read-out at that concentration, not a potency): 76%
For compound 4 the middle estimate is 9 percentage points above the measured one, and the stated range covers the measured number.
By their numbers in this assay, from the lowest: compounds 2 and 3 (each within the scatter of the next); then compound 4; then compound 1.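

In this assay, the phenyl ring on this chain carbon proves to matter far more than the bromo it can carry: replacing phenyl with methyl gives a number 53 percentage points higher from compound 3 to compound 4 (beyond the scatter), and replacing 4-bromophenyl with methyl gives a number 61 percentage points higher from compound 2 to compound 4 (beyond the scatter), whereas removing the bromo alone stayed within the scatter. Losing the ring does not settle the number on its own, as the two ring-free side chains also differ, with 2-hydroxypropyl in place of 1,2-dihydroxyethyl giving a number 33 percentage points lower from compound 1 to compound 4 (beyond the scatter). Nothing shown here explains why either change moves the read-out this far.

On these data alone, it remains open whether this carbon needs an aromatic ring specifically or whether a non-aromatic group such as cyclohexyl, or a longer chain, would give a similarly low number. Every compound shown also keeps a hydroxyl on its chain, and the effect of replacing that hydroxyl on the phenyl-bearing chain with an amine or a ketone is likewise unknown.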